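From compound 3 to compound 4: a side-chain exchange

The compounds below may be only part of what the source reports. "The series", "measured", "known", "first", "only" and "open" are said of these compounds alone.

Measured so far in an ADME assay on microsomes from liver (Rattus norvegicus) for metabolic stability, read by LC-MS, with a stated time of 10 min, tested at 0.5 uM (a higher number here means that more of the compound is left, a lower number that less of the compound is left), with these results
- compound 1 `c1ccc2c(c1)CN[C@@H](CN(CC[C@@H]1CCCNC1)[C@H]1CCCc3cccnc31)C2` gives 28%
- compound 2 `CN1CCN(CCCN(C[C@H]2Cc3ccccc3CN2C)[C@H]2CCCc3cccnc32)CC1` gives 2%
- compound 3 `c1ccc2c(c1)CN[C@@H](CN(CC[C@H]1CCCNC1)[C@H]1CCCc3cccnc31)C2` gives 55%

Compound 3 stands highest of the three at 55% and lies beyond the scatter from both others. Compound 4 `CN1CCN(CCCN(C[C@H]2Cc3ccccc3CN2)[C@H]2CCCc3cccnc32)CC1` is still unmeasured. The change to it reads (4-methylpiperazin-1-yl)methyl in place of piperidin-3-yl on a saturated chain carbon, two bonds along the chain from an amine nitrogen and puts (4-methylpiperazin-1-yl)methyl in place of piperidin-3-yl on a saturated chain carbon, two bonds along the chain from an amine nitrogen. Going by the values given here, the only measured step shows a number 27 percentage points higher from compound 1 to compound 3 (beyond the scatter) and concerns configuration alone (the fact that compounds 1 and 3 differ only in the configuration as drawn) so it does not size this exchange. Compound 2 also carries 2-(4-methylpiperazin-1-yl)ethyl and gives 2% in this assay which points to a large fall beyond the scatter. The expected move is a number 40 percentage points lower from compound 3 to compound 4 (beyond the scatter) as an estimate. Compound 4 is expected at 15% within 3% to 35% as an estimate.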

Compound 4, percent of the compound remaining: 10%
For compound 4 the middle estimate is 5 percentage points above the measured one; the range from low to high includes it.
By their numbers in this assay, from the lowest: compounds 2 and 4 (each within the scatter of the next); then compound 1; then compound 3.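

In this assay, (4-methylpiperazin-1-yl)methyl in place of piperidin-3-yl on a saturated chain carbon, two bonds along the chain from an amine nitrogen, gives a fall from either configuration of the leaving group: a number 45 percentage points lower from compound 3 to compound 4 (beyond the scatter) and a number 18 percentage points lower from compound 1 to compound 4 (beyond the scatter). Hydrogen in place of methyl on an amine nitrogen in a ring stays within the scatter, with a number 8 percentage points higher from compound 2 to compound 4 (within the scatter). Nothing at hand gives a cause for the fall on this exchange.

Open, on these data alone, is whether a morpholin-4-yl group at this place would keep more of the compound. Also open, as far as these compounds go, is how a piperazin-1-yl group without the methyl would behave.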